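A Methoxyphenyl Swap on Compound 3

This account rests on a few compounds, and the source may have more. Where it says the series, first, only, none or still open, it means among the compounds named here.

Three related compounds have been measured in a functional assay on MCF7 cells (Homo sapiens) for cytotoxicity, read by MTT assay, with a stated time of 72 h; a higher number here means a weaker inhibitor, a lower number a stronger inhibitor. Compound 1 `O=C(N/N=C/c1cccc(Br)c1)Nc1cc2c(Nc3ccc(F)c(Cl)c3)ncnc2cc1O[C@H]1CCOC1` gives 12400 nM. Compound 2 `COc1cc(/C=N/NC(=O)Nc2cc3c(Nc4ccc(F)c(Cl)c4)ncnc3cc2O[C@H]2CCOC2)cc(OC)c1OC` gives 26500 nM, and compound 3 `COc1cc2ncnc(Nc3ccc(F)c(Cl)c3)c2cc1NC(=O)N/N=C/c1cccc(Br)c1` gives 27100 nM. Compounds 2 and 3 therefore sit level within the usual scatter, and both are weaker than compound 1.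

Compound 4 `COc1ccc(/C=N/NC(=O)Nc2cc3c(Nc4ccc(F)c(Cl)c4)ncnc3cc2OC)cc1` differs from compound 3 in one place: 4-methoxyphenyl in place of 3-bromophenyl on a carbon with a double bond to nitrogen. Going by the values given here, the closest precedent is at that same place, where 3,4,5-trimethoxyphenyl in place of 3-bromophenyl gave a 2.1-fold higher number from compound 1 to compound 2 (0.33 log units; beyond the scatter), a modest step. The other measured change, a 2.2-fold higher number from compound 1 to compound 3 (0.34 log units; beyond the scatter), is at a different place and is already part of compound 3, so it offers little guidance. With one modest precedent, made on a different background, no step beyond the scatter is expected, only a slight lean towards a higher number. The expected change is a 1.2-fold higher number from compound 3 to compound 4 (0.07 log units; within the scatter). For compound 4 the estimated value is 32000 nM, with an expected range from 15000 nM to 65000 nM.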

Compound 4, half-maximal inhibitory concentration: 8140 nM
Estimate against measurement, compound 4: 3.9-fold (0.59 log units) above; the whole stated range lies above it.
By their numbers in this assay, from the lowest: compounds 4 and 1 (each within the scatter of the next); then compounds 2 and 3 (each within the scatter of the next).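

In this assay, changing the group on the carbon with a double bond to nitrogen does not push the number in only one direction. Replacing 3-bromophenyl with 3,4,5-trimethoxyphenyl gave a 2.1-fold higher number from compound 1 to compound 2 (0.33 log units; beyond the scatter), whereas replacing it with 4-methoxyphenyl gave a 3.3-fold lower number from compound 3 to compound 4 (0.52 log units; beyond the scatter), so leaving 3-bromophenyl can go either way, though the two steps stand on different backgrounds and the entering group and the background cannot be told apart as the source of the difference. No measurement here explains the direction or size of the new step.

Going by these compounds, it remains open whether 4-methoxyphenyl gives a similar step when the oxygen on the aromatic ring carries oxolan-3-yl instead of methyl. On these data alone, how a phenyl ring carrying an amine or a carboxylic acid would behave at this position is also open.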